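Amino substitution on the pendant phenyl of compound 1

The source may hold more compounds than are shown below. What is called first, only, known or untested is meant among the compounds shown, and "the series" means these compounds.

Compound 1 `CCCS(=O)(=O)Nc1ccc(F)c(C(=O)c2n[nH]c3ncc(-c4ccccc4)cc23)c1F` is the reference point of the series. In an assay for binding affinity to dual specificity mitogen-activated protein kinase kinase 4 (Homo sapiens), read by KINOMEscan, tested at 100 nM (on this read-out lower numbers stand for a stronger effect and higher numbers for a weaker effect at the one concentration tested), compound 1 gives 2.4%, the lowest of the three numbers recorded so far. Compound 2 `CCCS(=O)(=O)Nc1ccc(F)c(C(=O)c2n[nH]c3ncc(-c4ccccc4O)cc23)c1F` gives 9% and compound 3 `CCCS(=O)(=O)Nc1ccc(F)c(C(=O)c2n[nH]c3ncc(-c4ccccc4N)cc23)c1F` gives 23%. The step of a number 6.6 percentage points higher from compound 1 to compound 2 (within the scatter) stays within the scatter, whereas a number 20.6 percentage points higher from compound 1 to compound 3 (beyond the scatter) and a number 14 percentage points higher from compound 2 to compound 3 (beyond the scatter) lie beyond it, both modest.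

Compound 4 `CCCS(=O)(=O)Nc1ccc(F)c(C(=O)c2n[nH]c3ncc(-c4cccc(N)c4)cc23)c1F` differs from compound 1 by amino in place of hydrogen on an aromatic carbon. The entering group is the same as in compound 3, but here it sits meta to a large group, while compound 3 carries it on another carbon of that ring. The step of a number 20.6 percentage points higher from compound 1 to compound 3 (beyond the scatter) is the only measured one that introduces an amino group and is therefore the nearest guide; it points to a modest weakening. The placement differs, so the transfer is uncertain and a result within the scatter cannot be excluded. Compound 4 is expected to show a number 12.6 percentage points higher from compound 1 to compound 4 (beyond the scatter), a modest weakening. The estimate for compound 4 is 15%, with a range from 4% to 35%.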

Compound 4, a percentage reported as activity, at one concentration (the size of the read-out at that concentration, not a potency): 1.6%
The estimate for compound 4 lay 13.4 percentage points above the measured number; measured number below the stated range.
By their numbers in this assay, from the lowest: compounds 4, 1 and 2 (each within the scatter of the next); then compound 3.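

In this assay the step of a number 0.8 percentage points lower from compound 1 to compound 4 (within the scatter) shows that an amino group on this ring need not weaken the read-out: meta to a large group, it leaves the number unchanged within the scatter. For the compounds shown here, the step of a number 21.4 percentage points lower from compound 3 to compound 4 (beyond the scatter) is the first to compare two placements of the same group, so the loss seen with compound 3 goes with where the amino group sits, not with its presence alone, while the step of a number 7.4 percentage points lower from compound 2 to compound 4 (within the scatter) leaves compound 2 and compound 4 unseparated. Nothing available explains this dependence on placement.

On these data alone, whether the same carbon accepts other groups, such as a methoxy, a carboxylic acid or a dimethylamino group, stays open. Whether a larger amine or a longer chain there would keep the read-out of compound 4 is also unknown.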